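Nitro in place of chloro on an aromatic carbon

The source may hold more compounds than are shown below. What is called first, only, known or untested is meant among the compounds shown, and "the series" means these compounds.

In a functional assay on ASPC1 cells (Homo sapiens) for inhibition, read by MTT assay, with a stated time of 72 h (a higher number here means that more compound is tolerated, a lower number that less compound is tolerated), compound 1 `CC(C)(Oc1ccc(CCOc2ccc(NC(=O)c3ccccc3)cc2)cc1)C(=O)NS(=O)(=O)c1ccccc1` gives 7000 nM as a measured value. Compound 2 `CC(C)(Oc1ccc(CCOc2ccc(/N=N/c3ccccc3)cc2)cc1)C(=O)NS(=O)(=O)c1ccc(Cl)cc1` stands at > 24000 nM which is only a limit of the assay and not a number. Compound 3 `CC(C)(Oc1ccc(CCOc2ccc(/N=N/c3ccccc3)cc2)cc1)C(=O)NS(=O)(=O)c1ccc([N+](=O)[O-])cc1` differs from compound 2 by nitro in place of chloro on an aromatic carbon and in nothing else. Among the compounds with values here, no measured step shows such an exchange, so no change beyond the scatter is expected in this assay and no direction is favoured. The expected change is an at least 1.2-fold lower number from compound 2 to compound 3 (0.07 log units; that floor lies within the scatter) as estimated here. For compound 3 the expected value is 20000 nM (estimated range 8000 nM to 40000 nM).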

Compound 3, half-maximal cytotoxic concentration: > 24000 nM
Compound 3: a limit, no number; the forecaster's own chance of this, stated with the estimate: 50%; at least 1.2-fold (0.07 log units) between middle value and limit.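

In this assay compound 2 and compound 3 each give only a limit and not a number, so no step can be read between them: the limit of > 24000 nM in this assay, at which 2 of the 3 values shown sit. The compounds shown leave open whether nitro in place of chloro on an aromatic carbon changes the value at all, and in which direction.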